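Extending the Chain of Compound 2 Further

The source may report more compounds than this note shows. Statements on the series, on what has been measured and on what is new or still open speak of the compounds shown alone.

Going by the values given here, in a functional assay on brain (Rattus norvegicus, strain Wistar) for inhibition (a lower number here means a stronger inhibitor, a higher number a weaker inhibitor), compound 2 `CCCCCCCc1ccc(-c2c(C)[nH]c(=O)n2C2CCCCC2)cc1` gives 8700 nM as the lower of the two known numbers, while compound 1 `CCCCc1ccc(-c2c(C)[nH]c(=O)n2C2CCCCC2)cc1` gives 27100 nM with its shorter chain. Compound 3 `CCCCCCCCCCCCCCc1ccc(-c2c(C)[nH]c(=O)n2C2CCCCC2)cc1` differs from compound 2 by heptyl in place of hydrogen on a saturated chain carbon, seven bonds along the chain from an aromatic carbon on the same core. Among the compounds with values here, the only measured step bearing on this is a 3.1-fold lower number from compound 1 to compound 2 (0.49 log units; beyond the scatter), which is modest. One step fixes no trend, so only a small further fall in this assay is expected, and a reversal remains possible. The expected change is a 1.7-fold lower number from compound 2 to compound 3 (0.24 log units; within the scatter) overall. Compound 3 is estimated at 5000 nM, with an expected range from 1200 nM to 30000 nM.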

Compound 3, half-maximal inhibitory concentration: > 100000 nM
Compound 3 ended at the assay's limit; the forecaster's own chance of this, stated with the estimate: 15%; middle value at least 20-fold (1.30 log units) from the limit.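

In this assay compound 3 gives > 100000 nM, which is a limit of the assay and not a number. The fall seen on first lengthening the chain does not continue at this position: adding heptyl gives an at least 11-fold higher number from compound 2 to compound 3 (1.06 log units; beyond the scatter). Adding decyl to the shorter chain gives an at least 3.6-fold higher number from compound 1 to compound 3 (0.56 log units; beyond the scatter), so the longest chain shown also ends with a higher number than the shortest.

Going by these compounds, the chain length at which the direction turns remains open, since a decyl chain would fall within the gap. Also open, on these data alone, is how a chain carrying an amine or a carboxylic acid would read here.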